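The source may report more compounds than this note shows. Statements on the series, on what has been measured and on what is new or still open speak of the compounds shown alone.

Two compounds share one core and differ only in the group on an amine nitrogen. In a functional assay on LNCaP cells (Homo sapiens) for antiproliferative activity, read by CCK-8 assay, with a stated time of 6 days (on this read-out lower numbers stand for stronger inhibition and higher numbers for weaker inhibition), compound 1 `C[C@@H](Cn1ccc(-c2ccc(C#N)c(Cl)c2)n1)NC(=O)C1CC(=O)C1` gives 3040 nM. Compound 2 `C[C@@H](Cn1ccc(-c2ccc(C#N)c(Cl)c2)n1)Nc1ccccc1` gives 710 nM, the lower of the two numbers, and the step of a 4.3-fold lower number from compound 1 to compound 2 (0.63 log units; beyond the scatter) lies beyond the scatter. Compound 3 `C[C@@H](Cn1ccc(-c2ccc(C#N)c(Cl)c2)n1)Nc1ccncc1` carries pyridin-4-yl in place of phenyl on an amine nitrogen. For the measured compounds named here, the single measured step exchanged the (3-oxocyclobutyl)carbonyl group for phenyl, not one aromatic ring for another, so it bears only loosely on this swap, and no step beyond the scatter is expected in either direction. Compound 3 is therefore estimated at 1000 nM, within 300 nM to 3500 nM, an expected step of a 1.4-fold higher number from compound 2 to compound 3 (0.15 log units; within the scatter).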

Compound 3, half-maximal inhibitory concentration: 2560 nM
Compound 3: the middle estimate sits 2.6-fold (0.41 log units) below what was measured, and the stated range covers the measured number.
By their numbers in this assay, from the lowest: compound 2; then compounds 3 and 1 (each within the scatter of the next).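

In this assay, a small edit to the ring on this amine nitrogen is enough to move the number: pyridin-4-yl in place of phenyl, with one ring carbon exchanged for nitrogen, gives a 3.6-fold higher number from compound 2 to compound 3 (0.56 log units; beyond the scatter). Having an aromatic ring at this position therefore does not by itself secure the lower number, since the comparison with the non-aromatic acyl group shows a 1.2-fold lower number from compound 1 to compound 3 (0.07 log units; within the scatter). Nothing measured here explains why the ring nitrogen has this effect. Still open, going by these compounds, is how a pyridin-3-yl or pyridin-2-yl ring would compare, and whether a phenyl ring carrying a fluorine or a methoxy group would match compound 2.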